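A few compounds are considered here, and "the series" means these few. Any claim that something is new, unique, unknown or untested is made for them only; others in the source may bear on it.

In a functional assay on MCF7 cells (Homo sapiens) for antiproliferative activity, read by CellTiter-Glo, with a stated time of 5 days (a lower number here means a stronger inhibitor, a higher number a weaker inhibitor), compound 3 `CC/C(=C(/c1ccc(/C=C/C(=O)O)cc1)c1ccc(-c2cscn2)cc1)c1ccccc1` gives 120 nM, and compound 1 `CC/C(=C(/c1ccc(/C=C/C(=O)O)cc1)c1ccc2nccn2c1)c1ccccc1` gives 170 nM, two numbers within the usual scatter of each other. Compound 2 `CC/C(=C(/c1ccc(/C=C/C(=O)O)cc1)c1ccc2sncc2c1)c1ccccc1` is reported only as a limit, > 500 nM. For the measured compounds named here, compound 3 therefore has the lowest actual number so far, though not one that clearly separates it from compound 1.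

Compound 4 `CC/C(=C(/c1ccc(/C=C/C(=O)O)cc1)c1ccc(-c2cn[nH]c2)cc1)c1ccccc1` has 1H-pyrazol-4-yl in place of 1,3-thiazol-4-yl on an aromatic carbon, para to a large group (1H-pyrazol-4-yl in place of 1,3-thiazol-4-yl on an aromatic carbon). Going by the values given here, only one measured step offers any guide: an at least 2.9-fold higher number from compound 1 to compound 2 (0.46 log units; beyond the scatter). There, a group containing sulfur replaced one whose ring hetero atoms were all nitrogen, and the number rose. The change to compound 4 also swaps sulfur-containing for all-nitrogen hetero atoms, but in the opposite direction and on a different group, so this is only a weak hint.

The expected change, a 1.2-fold lower number from compound 3 to compound 4 (0.08 log units; within the scatter), is small, probably within the scatter, and leans slightly towards a lower number. For compound 4 the estimated value is 100 nM, with an expected range of 40 nM to 300 nM.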

Compound 4, half-maximal inhibitory concentration: 40 nM
Beside the measured number, compound 4's estimate is 2.5-fold (0.40 log units) above it; measured number inside the range.
By their numbers in this assay, from the lowest: compound 4; then compounds 3 and 1 (each within the scatter of the next). At a limit, above all of these: compound 2.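

Swapping 1,3-thiazol-4-yl for 1H-pyrazol-4-yl gives, in this assay, a 3.0-fold lower number from compound 3 to compound 4 (0.48 log units; beyond the scatter). The group on this aromatic carbon, para to a large group, therefore affects the number: the assay separates two groups with the same count of heavy atoms, each a five-membered aromatic ring with 2 hetero atoms. The entering group has nitrogen in place of sulfur and 1 hydrogen-bond donor in place of 0, but these two differences arrive together, and nothing available explains the step.

Still open, going by these compounds, is how a 1-methyl-1H-pyrazol-4-yl group, which keeps the ring but has a methyl in place of the hydrogen on nitrogen, would compare. Also open, on these data alone, is whether an open-chain group at this carbon, such as an amine or an amide, could match the pyrazole.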